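Pyrimidinyl piperazine replaces the free amine in compound 3

The source may hold more compounds than are shown below. What is called first, only, known or untested is meant among the compounds shown, and "the series" means these compounds.

This account follows one step in a small series sharing a tryptamine-like core. In an assay on CHO cells for displacement of a labelled ligand from 5-hydroxytryptamine receptor 1D (Homo sapiens) (on this read-out higher numbers stand for weaker inhibition and lower numbers for stronger inhibition), compound 1 `c1ccc(CN2CCN(CCCc3c[nH]c4ccc(-n5cnnc5)cc34)CC2)nc1` gives 0.4 nM, compound 2 `CC(=O)Nc1ccc(CN2CCN(CCCc3c[nH]c4ccc(-n5cnnc5)cc34)CC2)cc1` gives 2.5 nM, and compound 3 `c1cc2[nH]cc(CCCN3CCNCC3)c2cc1-n1cnnc1` gives 31 nM, the highest of the three numbers and beyond the scatter from both of the others. Compound 4 `c1cnc(N2CCN(CCCc3c[nH]c4ccc(-n5cnnc5)cc34)CC2)nc1` is not yet measured. Its change from compound 3 is pyrimidin-2-yl in place of hydrogen on an amine nitrogen in a ring; the entering group is bound directly to the ring nitrogen, without the saturated chain carbon seen in compounds 1 and 2.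

Among the compounds with values here, two measured steps bear on this change, read in reverse. Replacing the ring hydrogen with a (pyridin-2-yl)methyl group gave a 78-fold higher number from compound 1 to compound 3 (1.89 log units; beyond the scatter) the other way round, and replacing it with a 4-acetamidobenzyl group gave a 12-fold higher number from compound 2 to compound 3 (1.09 log units; beyond the scatter) the other way round. Both substitutions on this nitrogen lowered the number by a large margin. Within the data shown here, because compound 3 at 31 nM sits well above compounds 1 and 2, a substantial drop is expected for compound 4 in this assay, although the direct ring attachment has no measured counterpart here, so the expected step is kept smaller than either measured one. Compound 4 is therefore estimated at 5 nM, with a range from 1.5 nM to 16 nM, an expected step of a 6.2-fold lower number from compound 3 to compound 4 (0.79 log units; beyond the scatter).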

Compound 4, half-maximal inhibitory concentration: 0.6 nM
Estimate against measurement, compound 4: 8.3-fold (0.92 log units) above; the measured number lies below the stated range.
By their numbers in this assay, from the lowest: compounds 1 and 4 (each within the scatter of the next); then compound 2; then compound 3.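

In this assay, a 52-fold lower number from compound 3 to compound 4 (1.71 log units; beyond the scatter) shows that this ring nitrogen needs no saturated chain carbon to reach the low end of the series, since pyrimidin-2-yl bound directly to it does as much as the groups attached through such a carbon. The comparison with the two substituted compounds separates them: the change gives a 4.2-fold lower number from compound 2 to compound 4 (0.62 log units; beyond the scatter), while the other comparison gives a 1.5-fold higher number from compound 1 to compound 4 (0.18 log units; within the scatter), so the directly bound pyrimidin-2-yl and the (pyridin-2-yl)methyl group cannot be told apart on this read-out, and only 4-acetamidobenzyl falls short of both. No supporting measurement accompanies these values, so they offer no explanation for the size of the steps.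

As far as these compounds go, whether the two ring nitrogens of pyrimidin-2-yl matter stays open, as a phenyl or pyridin-2-yl ring bound directly to the same nitrogen would be needed to tell. The compounds shown also leave open whether an aromatic ring is needed here at all, which a small group such as methyl or acetyl on this nitrogen would test, and whether the result holds with a shorter or longer chain to the core.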